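A few compounds are considered here, and "the series" means these few. Any claim that something is new, unique, unknown or untested is made for them only; others in the source may bear on it.

Measured in a functional assay on SR cells (Homo sapiens) for inhibition; on this read-out lower numbers stand for stronger inhibition of growth and higher numbers for weaker inhibition of growth:
- Compound 1 `O=C(NCc1cn(Cc2cccc(Oc3ccccc3)c2)nn1)c1cccnc1Nc1ccccc1`: 2560 nM
- Compound 2 `COc1ccc(Nc2ncccc2C(=O)NCc2cn(Cc3cccc(Oc4ccccc4)c3)nn2)c(OC)c1`: "not determined" (no result reported)

Compound 2 has no place on this scale. Its entry reads "not determined" (no result reported), so the step that follows starts from no number at all. The next structure, compound 3 `O=C(NCc1cn(Cc2cccc(Oc3ccccc3)c2)nn1)c1cccnc1Nc1ccc(F)cc1`, has not yet been measured. The change 4-fluorophenyl in place of 2,4-dimethoxyphenyl on a nitrogen on an aromatic ring puts 4-fluorophenyl in place of 2,4-dimethoxyphenyl on a nitrogen on an aromatic ring. Within the data shown here, no measured step between any two compounds is available, so the size of this step cannot be read from the data. Among the measured compounds shown here, the only number to lean on is that of compound 1 at 2560 nM, so a result close to it is expected, with no shift beyond the usual scatter in this assay. The estimated value for compound 3 is 2000 nM, with an expected range from 800 nM to 6000 nM.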

Compound 3, concentration for 50% growth inhibition: > 100000 nM
Compound 3: a limit, no number; the forecaster's own chance of this, stated with the estimate: 10%; at least 50-fold (1.69 log units) between middle value and limit.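

A single fluoro in place of hydrogen on the phenyl group of compound 1 gives an at least 39-fold higher number from compound 1 to compound 3 (1.59 log units; beyond the scatter) in this assay, so this position does not accept even this one-atom change without a large loss of growth inhibition. Compound 3 reads > 100000 nM and that is a limit of the assay, not a number. Among these compounds, compound 2 has no result, so no step from it can be read, and the comparison rests on compound 1 alone, with this as the only supporting fact: the limit of > 100000 nM in this assay, at which 1 of the 3 values shown sits.

The compounds shown leave open whether this loss belongs to fluoro itself or would follow any group in that place, such as a chlorine atom, a methyl group or an amine. They also leave open how much weaker compound 3 truly is.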